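A few compounds are considered here, and "the series" means these few. Any claim that something is new, unique, unknown or untested is made for them only; others in the source may bear on it.

Compound 2 `N#Cc1ncn(Cc2ccccc2Cl)c1/N=C/c1ccc(O)cc1` is one of three compounds sharing a core and differing only in the aromatic ring attached through the imine. In a functional assay on A549 cells (Homo sapiens) for antiproliferative activity, read by MTT assay (a higher number here means a weaker inhibitor, a lower number a stronger inhibitor), compound 2 gives 35100 nM, the highest of the three numbers, yet its companions lie within the usual scatter of it: compound 3 `N#Cc1ncn(Cc2ccccc2Cl)c1/N=C/c1ccc(Cl)cc1` gives 30800 nM and compound 1 `COc1ccc(OC)c(/C=N/c2c(C#N)ncn2Cc2ccccc2Cl)c1` gives 18000 nM. The unmeasured compound 4 `COc1cc(/C=N/c2c(C#N)ncn2Cc2ccccc2Cl)ccc1O` differs from compound 2 by methoxy in place of hydrogen on an aromatic carbon. For the measured compounds named here, the only single-point step recorded on this ring, the swap from compound 2 to compound 3, was a 1.1-fold lower number from compound 2 to compound 3 (0.06 log units; within the scatter), so one exchange on this ring left the number where it was. Compound 1, carrying two methoxy groups and no hydroxy, shows a number only modestly apart from that of compound 2, again within the scatter. Nothing among these three suggests that adding a methoxy group would move the number beyond the scatter, so for compound 4 the expected step is a 1.2-fold lower number from compound 2 to compound 4 (0.07 log units; within the scatter), essentially no change. Compound 4 is therefore estimated at 30000 nM, with a likely range from 12000 nM to 75000 nM.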

Compound 4, half-maximal inhibitory concentration: 39000 nM
Compound 4: middle estimate off by 1.3-fold (0.11 log units), on the low side, within the range that was stated.
By their numbers in this assay, from the lowest: compounds 1, 3, 2 and 4 (each within the scatter of the next, the first and the last beyond it).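

Putting methoxy in place of hydrogen on the aromatic carbon ortho to the hydroxy group gives, in this assay, a 1.1-fold higher number from compound 2 to compound 4 (0.05 log units; within the scatter), so the number stays where it was. The earlier compounds shown here could not show this: the step from compound 2 to compound 3 exchanges the hydroxy group itself, and compound 1 differs from compound 2 in more than one place, whereas here the hydroxy group stays and a single group is added at a new position on the ring. Nothing measured here explains why the added methoxy group leaves the number unchanged.

On these data alone, whether an amine, a carboxylic acid or a longer chain at this position would move the number beyond the scatter remains open. So does whether methoxy would behave the same way on this ring without the hydroxy group.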